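The source may hold more compounds than are shown below. What is called first, only, known or untested is meant among the compounds shown, and "the series" means these compounds.

In a functional assay on COLO 205 cells (Homo sapiens) for cytotoxicity, read by sulforhodamine B assay, with a stated time of 48 h, tested at 0.01 uM (a lower number here means a stronger effect, a higher number a weaker effect of the compound at the concentration tested), three compounds sharing one core have been measured. Compound 1 `COc1cc(C)cc(-c2nn(CC#N)cc2-c2ccc(-c3cccc(C(C)=O)c3)nc2)c1` gives 100% in this assay. Compound 2 `Cc1cc(O)cc(-c2nn(CC#N)cc2-c2ccnc(-c3ccc(Oc4ccccc4)cc3)c2)c1` gives 99%. Compound 3 `COc1cc(C)cc(-c2nn(CC#N)cc2-c2ccnc(-c3ccc(N(C)C)cc3)c2)c1` gives 116%. Of these three numbers compound 3 stands highest: its nearest neighbour is compound 1, a step beyond the scatter below it, and compound 2 lies a little further below. Since a lower number means a stronger effect, compound 3 shows the weakest effect of the three at the concentration tested, while compounds 1 and 2 lie within the scatter of each other and show no order between them.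

Compound 4 `Cc1cc(O)cc(-c2nn(CC#N)cc2-c2ccnc(-c3ccc(N(C)C)cc3)c2)c1` has not yet been measured. It differs from compound 3 in a single place: hydrogen in place of methyl on an oxygen on an aromatic ring. Among the measured compounds shown here, no two measured compounds differ in only one place, so there is no measured step of this kind to lean on. Compound 2 carries the same hydroxy group but a different group on the other side of the core, so it offers only a loose hint. The step from compound 3 to compound 4 is expected to amount to a number 10 percentage points lower from compound 3 to compound 4 (within the scatter), a small move downward that may not exceed the scatter. Compound 4 is expected to give 106%, with a range from 90% to 120%, partly because compound 2 with the same hydroxy group gives 99%.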

Compound 4, a percentage reported as activity, at one concentration (the size of the read-out at that concentration, not a potency): 95%
Compound 4: middle estimate off by 11 percentage points, on the high side, and the stated range covers the measured number.
By their numbers in this assay, from the lowest: compounds 4, 2 and 1 (each within the scatter of the next); then compound 3.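

In this assay, methoxy to hydroxy on the 3-methoxy-5-methylphenyl group, with everything else held the same, gives a number 21 percentage points lower from compound 3 to compound 4 (beyond the scatter) and is the only single change among these compounds that moves the read-out beyond the usual scatter. So the methyl on this oxygen is not a silent detail: with hydrogen in its place, the effect at the one concentration tested is stronger, although this says nothing about potency. Among the compounds shown here, with the hydroxy group kept, dimethylamino in place of phenoxy on an aromatic carbon gives a number 4 percentage points lower from compound 2 to compound 4 (within the scatter) and leaves no order between this pair, so a large change at that other place shows up less here than the loss of one methyl on the oxygen.

Nothing at hand explains the methoxy to hydroxy step. The compounds shown leave open whether that step would look the same with phenoxy in place of dimethylamino, and how this position would respond to ethoxy, a longer ether chain or an amine in place of the hydroxy.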